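Moving a bromine around the ring: compound 2 to compound 3

A few compounds are considered here, and "the series" means these few. Any claim that something is new, unique, unknown or untested is made for them only; others in the source may bear on it.

Compound 1 `COc1ccc(/C=C2\NS(=O)(=O)c3ccccc3C2=O)cc1` gives 1530 nM in an assay for inhibition of Intestinal-type alkaline phosphatase (Homo sapiens), read by spectrophotometry, with stated times of 10 min and 20 min; a lower number here means a stronger inhibitor, a higher number a weaker inhibitor
Compound 2 `O=C1/C(=C/c2cccc(Br)c2)NS(=O)(=O)c2ccccc21` gives 2550 nM in this assay

Compound 2 and compound 1 give numbers that fall within the usual scatter of each other, so the two cannot be told apart on these figures. Compound 3 `O=C1/C(=C/c2ccc(Br)cc2)NS(=O)(=O)c2ccccc21` differs from compound 2 only in this: 4-bromophenyl in place of 3-bromophenyl on a double-bonded chain carbon bound to a double-bonded ring carbon. Among the measured compounds shown here, no measured pair shows what such a move does here. With nothing pointing either way, the step from compound 2 to compound 3 in this assay is expected to stay within the scatter, estimated as a 1.3-fold lower number from compound 2 to compound 3 (0.11 log units; within the scatter). Compound 3 is thus expected to give about 2000 nM, likely between 700 nM and 6000 nM.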

Compound 3, half-maximal inhibitory concentration: 3690 nM
For compound 3 the middle estimate is 1.8-fold (0.27 log units) below the measured one; low and high end bracket the measured number.
By their numbers in this assay, from the lowest: compounds 1, 2 and 3 (each within the scatter of the next, the first and the last beyond it).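

Moving the bromine, with 4-bromophenyl in place of 3-bromophenyl, gives a 1.4-fold higher number from compound 2 to compound 3 (0.16 log units; within the scatter) in this assay, so these two placements cannot be told apart on these figures. Bromo in place of methoxy on an aromatic carbon gives a 2.4-fold higher number from compound 1 to compound 3 (0.38 log units; beyond the scatter), a modest step and the only one here beyond the scatter. Nothing available explains either step. Going by these compounds, whether an amine or a carboxylic acid in place of the bromine would shift the number beyond the scatter remains open.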